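A Benzyl-to-Trifluoromethylphenyl Swap and Acid Dissociation

A few compounds are considered here, and "the series" means these few. Any claim that something is new, unique, unknown or untested is made for them only; others in the source may bear on it.

Three compounds have been measured so far:

Compound 1, `COc1cccc(CNCCCNc2ccnc3cc(Oc4ccc(Cl)cc4)ccc23)c1O`: 9.28
Compound 2, `COc1ccc(Oc2ccc3c(NCCCNCc4cccc(OC)c4O)ccnc3c2)cc1`: 9.28
Compound 3, `COc1cccc(CNCCCNc2ccnc3cc(Cc4ccccc4)ccc23)c1O`: 9.47

The read-out throughout is a physicochemical assay for acid dissociation. Compound 3 has the highest of the three numbers, yet its nearest neighbour compound 1 sits only a number 0.19 log units higher from compound 1 to compound 3 (within the scatter), and its furthest neighbour compound 2 sits only a number 0.19 log units higher from compound 2 to compound 3 (within the scatter), so the three compounds cannot be told apart on this read-out. The step from compound 1 to compound 2 likewise shows no change at the digits printed from compound 1 to compound 2 (within the scatter).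

Compound 4, `COc1cccc(CNCCCNc2ccnc3cc(-c4ccc(C(F)(F)F)cc4)ccc23)c1O`, has not yet been measured. The change that takes compound 3 to compound 4 is 4-(trifluoromethyl)phenyl in place of benzyl on an aromatic carbon. The two steps that bear on it are the earlier changes at the same aromatic carbon of the shared core, from compound 1 to compound 3 and from compound 2 to compound 3, both within the scatter. On that evidence the group at this carbon has not moved the number, and the new group of compound 4 is expected to behave the same way, so the expected step of a number 0.12 log units lower from compound 3 to compound 4 (within the scatter) is none beyond the scatter. Compound 4 is therefore estimated at 9.35, with a range from 9 to 9.7.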

Compound 4, acid dissociation constant: 9.47
For compound 4 the middle estimate is 0.12 log units below the measured one; the range from low to high includes it.
By their numbers in this assay, from the lowest: compounds 1, 2, 3 and 4 (each within the scatter of the next).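

In this assay, 4-(trifluoromethyl)phenyl in place of benzyl gives a plain result (no change at the digits printed from compound 3 to compound 4 (within the scatter)), and the same group in place of the two phenoxy groups reads alike (a number 0.19 log units higher from compound 2 to compound 4 (within the scatter); a number 0.19 log units higher from compound 1 to compound 4 (within the scatter)). What is new is the kind of group that enters without a step beyond the scatter: this aromatic carbon now carries fluorine, 10 heavy atoms instead of the 7 of benzyl, and a ring joined directly to the shared core rather than through a linking atom, yet all four compounds still cannot be told apart on this read-out. No supporting measurement bears on why the number holds across these groups.

From the compounds shown here alone, every group at this carbon so far contains a six-membered aromatic ring of carbon only, so it remains open whether the number would also hold with an amine or a carboxylic acid there. The four compounds also share the same chain on the other side of the core, and a longer chain at that place could behave differently in this assay.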